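The compounds below may be only part of what the source reports. "The series", "measured", "known", "first", "only" and "open" are said of these compounds alone.

Measured so far:
compound 1 `CN(C)CCNc1nc(-c2ccc(NC(=O)Nc3ccc(Cl)cc3)cc2)nc2ccsc12` in a functional assay on MKN-45 cells (Homo sapiens) for cytotoxicity, read by MTT assay, with a stated time of 72 h; on this read-out lower numbers stand for stronger inhibition and higher numbers for weaker inhibition: 250 nM
compound 2 `CCN(CC)CCCNc1nc(-c2ccc(NC(=O)Nc3ccccc3F)cc2)nc2ccsc12` in this assay: 580 nM

Of these two numbers, compound 2 gives the higher one, and on this read-out that means the weaker inhibition. Compound 1 gives the lower number, and the gap between them is beyond the usual scatter, so compound 2 stands as the weaker of the pair.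

Compound 3 `CCN(CC)CCCNc1nc(-c2ccc(NC(=O)Nc3ccc(Cl)cc3)cc2)nc2ccsc12` has not yet been measured. It is built from compound 2 by a single change: 4-chlorophenyl in place of 2-fluorophenyl on an amide-type nitrogen. For the measured compounds named here, no pair of measured compounds shows this change on its own, so its size cannot be read from the data. Compound 1, which also carries the 4-chlorophenyl group, gives 250 nM, but compound 1 and compound 2 differ in more than this one place, so that number is only a loose pointer.

For compound 3, a modest move toward the lower number is expected, a step of a 1.7-fold lower number from compound 2 to compound 3 (0.22 log units; within the scatter) in this assay. The estimate for compound 3 is 350 nM, with a range from 150 nM to 800 nM.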

Compound 3, half-maximal inhibitory concentration: 180 nM
Compound 3: middle estimate off by 1.9-fold (0.29 log units), on the high side, within the range that was stated.
By their numbers in this assay, from the lowest: compounds 3 and 1 (each within the scatter of the next); then compound 2.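

In this assay, for the compounds shown here, putting 4-chlorophenyl in place of 2-fluorophenyl on the amide-type nitrogen gives a 3.2-fold lower number from compound 2 to compound 3 (0.51 log units; beyond the scatter) and lies beyond the scatter, so this is the first direct sign that the group at this position affects the read-out. The change at the other end of the molecule, (diethylamino)methyl in place of dimethylamino on a saturated chain carbon, gives a 1.4-fold lower number from compound 1 to compound 3 (0.14 log units; within the scatter) and stays within the scatter, so with 4-chlorophenyl in place this assay does not separate these two chain ends. Nothing measured alongside these numbers gives a reason for either result.

The step from 2-fluorophenyl to 4-chlorophenyl alters both the halogen and where it sits on the ring, and the compounds shown cannot separate the two; 4-fluorophenyl and 2-chlorophenyl would each isolate one of them. Also open, going by these compounds, is how far the result extends beyond these halogens, for instance to a plain phenyl or a 4-methoxyphenyl, and whether a chain ending in a morpholine behaves like the two amine ends seen here.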